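Adding a Methyl Group at Two Different Places

The source may hold more compounds than are shown below. What is called first, only, known or untested is meant among the compounds shown, and "the series" means these compounds.

Compound 1 `CCc1cc(=O)c2ccc(Sc3cccc(Cl)[n+]3[O-])cc2o1` and compound 2 `CCc1cc(=O)c2ccc(Sc3cccc(Cl)[n+]3[O-])c(C)c2o1` differ by one change: methyl in place of hydrogen on an aromatic carbon. In a functional assay on KBVIN cells (Homo sapiens) for antiproliferative activity, read by sulforhodamine B assay, with a stated time of 72 h (a higher number here means a weaker inhibitor of growth, a lower number a stronger inhibitor of growth), compound 1 gives only a limit, > 29900 nM. In this assay compound 2 likewise gives only a limit, > 28700 nM. The step that the two limits leave unreadable from compound 1 to compound 2 cannot be read because the limit of > 29900 nM in this assay, at which 1 of the 3 values shown sits, and the limit of > 28700 nM in this assay, at which 1 of the 3 values shown sits, sit at both of its ends.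

Compound 3 `CCc1cc(=O)c2ccc(OCc3ccccc3)c(C)c2o1` differs from compound 1 in more than one place, and the difference between the two cores is not broken down here. In this assay, within the data shown here, compound 3 gives 24800 nM, the only number among the three measured compounds. Compound 4 `CCc1cc(=O)c2ccc(OCc3cccc(C)c3)c(C)c2o1` is yet to be measured; it differs from compound 3 by methyl in place of hydrogen on an aromatic carbon. This is the same kind of change as from compound 1 to compound 2, but the place differs: there the aromatic carbon is part of a fused or bridged system of two rings, ortho to a fused ring, ortho to a group of 9 heavy atoms and meta to a fused ring; here it lies on a six-membered aromatic ring of carbon only, meta to a large group. Since the measured step has no readable size, the expectation rests on compound 3 alone, anchored on its value 24800 nM. Compound 4 is expected to show a step of a 1.1-fold higher number from compound 3 to compound 4 (0.04 log units; within the scatter), within the usual scatter. Compound 4 is therefore estimated at 27000 nM, between 12000 nM and 60000 nM.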

Compound 4, concentration for 50% growth inhibition: 24900 nM
For compound 4 the middle estimate is 1.1-fold (0.04 log units) above the measured one, within the range that was stated.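

In this assay, the change from phenyl to 3-methylphenyl gives a 1.0-fold higher number from compound 3 to compound 4 (0.00 log units; within the scatter), so on the core of compound 3 this methyl, on an aromatic carbon of a six-membered aromatic ring of carbon only, meta to a large group, shows no effect that can be told from the scatter. The same kind of change on the core of compound 1 offers no size to set beside it, and the step to compound 2 cannot be read because compound 1 gives only a limit, as does compound 2: the limit of > 29900 nM in this assay, at which 1 of the 4 values shown sits. Carrying the change from one core to the other is therefore not shown to hold or to fail, and the methyl also sits at a different place in each pair.

The compounds shown leave open whether an amine, a carboxylic acid or a longer chain in place of this methyl would give a value apart from that of compound 3 in this assay. They also leave open how a methyl at this same place would read on the core of compound 1.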